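Swapping the para substituent: hydroxy out, nitro in

This account rests on a few compounds, and the source may have more. Where it says the series, first, only, none or still open, it means among the compounds named here.

Of the compounds shown here, three have been tested in a functional assay on the whole organism with Mus musculus as the target, in the maximal electroshock model, with a stated time of 0.5 h; on this read-out lower numbers stand for an effect already at smaller amounts and higher numbers for an effect only at larger amounts of compound. Compound 1 `Fc1ccc(/C=N/NC(=S)Nc2nc3ccc(Cl)cc3s2)cc1` gives 30 mg/kg. Compound 2 `Oc1ccc(/C=N/NC(=S)Nc2nc3ccc(Cl)cc3s2)cc1` gives 100 mg/kg, and compound 3 `CC(C)(C)NCC(=O)Nc1nc2ccc(Cl)cc2s1`, which carries a different side chain on the shared core, gives 30 mg/kg. Within the data shown here, compound 2 therefore stands at the highest number of the three: the one measured step, a 3.3-fold higher number from compound 1 to compound 2 (0.52 log units; beyond the scatter), lies beyond the scatter, and the gap between compound 2 and compound 3 is of the same size.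

Compound 4 `O=[N+]([O-])c1ccc(/C=N/NC(=S)Nc2nc3ccc(Cl)cc3s2)cc1` is not yet measured. It differs from compound 2 as follows: nitro in place of hydroxy on an aromatic carbon. Among the measured compounds shown here, no measured step involves a nitro group, so the only guide is that the one change made so far at this position, a 3.3-fold higher number from compound 1 to compound 2 (0.52 log units; beyond the scatter), moved the number upward when hydroxy entered. Removing that hydroxy in favour of nitro is expected to reverse part of that move, so a modest step downward, a 2.0-fold lower number from compound 2 to compound 4 (0.30 log units; within the scatter), is estimated. The dose for compound 4 in this assay is expected near 50 mg/kg, with a range from 20 mg/kg to 150 mg/kg.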

Compound 4, minimum effective dose: 100 mg/kg
Compound 4: the middle estimate sits 2.0-fold (0.30 log units) below what was measured; measured number inside the range.
By their numbers in this assay, from the lowest: compounds 1 and 3 (each within the scatter of the next); then compounds 2 and 4 (each within the scatter of the next).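

In this assay the exchange of hydroxy for nitro gives no change at the digits printed from compound 2 to compound 4 (within the scatter) while the exchange of fluoro for nitro gives a 3.3-fold higher number from compound 1 to compound 4 (0.52 log units; beyond the scatter) at the same aromatic carbon. The higher number at this position is therefore not tied to hydroxy alone: nitro, with 0 hydrogen-bond donors, stands with hydroxy, and among these three groups only fluoro gives the lower number. No measurement offered here accounts for this result.

The compounds shown leave open whether an amine, a methoxy group or a chlorine atom at this position would stand with fluoro or with hydroxy and nitro. They also leave open what plain hydrogen at this place would give, so the effect of each group cannot yet be set against an unsubstituted ring.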